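From 4-chlorophenyl to sec-butoxy on the carbonyl

The compounds below may be only part of what the source reports. "The series", "measured", "known", "first", "only" and "open" are said of these compounds alone.

In a functional assay on MCF7 cells (Homo sapiens) for antiproliferative activity (a higher number here means a weaker inhibitor, a lower number a stronger inhibitor), compound 1 (`O=C(Nc1ccc(O)c2c(=O)cc(-c3ccccc3Cl)oc12)c1ccc(Cl)cc1`) gives 4600 nM and lies within the scatter of both measured neighbours: compound 2 (`COc1ccc(C(=O)Nc2ccc(O)c3c(=O)cc(-c4ccccc4Cl)oc23)cc1`) at 3500 nM and compound 3 (`O=C(Nc1c(O)cc(O)c2c(=O)cc(-c3ccccc3Cl)oc12)c1ccccc1`) at 8500 nM on the same scale. Compound 4 (`CCC(C)OC(=O)Nc1ccc(O)c2c(=O)cc(-c3ccccc3Cl)oc12`) carries sec-butoxy in place of 4-chlorophenyl on a carbonyl carbon. Within the data shown here, the only measured step bearing on this group (a 1.3-fold lower number from compound 1 to compound 2 (0.12 log units; within the scatter)) is methoxy in place of chloro on an aromatic carbon, and it stays within the scatter. Among the measured compounds shown here, no measured compound replaces the whole ring, so this guidance is thin and favours no direction. The expected change is a 1.1-fold higher number from compound 1 to compound 4 (0.04 log units; within the scatter) and thus no step beyond the scatter. The estimate for compound 4 is 5000 nM (expected range 1800 nM to 14000 nM).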

Compound 4, half-maximal inhibitory concentration: 30000 nM
The estimate for compound 4 lay 6.0-fold (0.78 log units) below the measured number; the measured number lies above the stated range.
By their numbers in this assay, from the lowest: compounds 2, 1 and 3 (each within the scatter of the next, the first and the last beyond it); then compound 4.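

On the carbonyl carbon, sec-butoxy is not an equivalent replacement for the aryl groups in this assay: it gives a 6.5-fold higher number from compound 1 to compound 4 (0.81 log units; beyond the scatter) and also an 8.6-fold higher number from compound 2 to compound 4 (0.93 log units; beyond the scatter) in the same direction. The methoxy-for-chloro change on the ring stayed within the scatter, whereas these replacements of the whole aryl group lie beyond it, so this position is sensitive to the larger change in these compounds. Nothing measured here accounts for the steps.

From the compounds shown here alone, it remains open whether losing the aromatic ring or introducing sec-butoxy matters more. A cyclohexyl or a benzyl group on the same carbonyl carbon would help separate the two.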